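The source may report more compounds than this note shows. Statements on the series, on what has been measured and on what is new or still open speak of the compounds shown alone.

Measured so far:
- compound 1, `CCCCCCCC/C(=C\C=C\C(=O)N[C@H](C)CCCc1cccnc1)c1ccc(OC)cc1`: 0.1 mg/kg
- compound 2, `COc1ccc(C(=C/C=C/C(=O)NCCCCc2cccnc2)c2ccc(OC)cc2)cc1`: 0.25 mg/kg

Both compounds were tested in a functional assay with platelet-activating factor receptor (Cavia porcellus) as the target; on this read-out lower numbers stand for an effect already at smaller amounts and higher numbers for an effect only at larger amounts of compound. Compound 1 holds the lowest of the two numbers: compound 2 needs a larger dose, and that gap lies beyond the scatter of repeated measurements. Compound 1 is therefore the reference point for the next step.

Compound 3, `COc1ccc(/C(=C/C=C/C(=O)N[C@H](C)CCCc2cccnc2)c2ccccc2)cc1`, has not yet been measured. It differs from compound 1 in one place: phenyl in place of octyl on a double-bonded chain carbon bound to an aromatic carbon and a double-bonded chain carbon. The two compounds share everything else, including the methyl-bearing chain that carries the pyridine end.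

Among the measured compounds shown here, no step between two measured compounds mirrors this change, so the expectation rests on the two values alone. Compound 2, which carries two aromatic rings at the corresponding position, still reaches a modest dose, which suggests that an aromatic ring in place of the octyl chain is tolerated. A small step toward higher numbers, close to the edge of the scatter, is expected, a 2.0-fold higher number from compound 1 to compound 3 (0.30 log units; within the scatter). Compound 3 is estimated at 0.2 mg/kg, with a likely range from 0.07 mg/kg to 0.6 mg/kg.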

Compound 3, dose for 50% inhibition: 0.16 mg/kg
The estimate for compound 3 lay 1.3-fold (0.10 log units) above the measured number; measured number inside the range.
By their numbers in this assay, from the lowest: compounds 1, 3 and 2 (each within the scatter of the next, the first and the last beyond it).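

In this assay the swap of octyl for phenyl on a double-bonded chain carbon bound to an aromatic carbon and a double-bonded chain carbon comes to a 1.6-fold higher number from compound 1 to compound 3 (0.20 log units; within the scatter) and so compound 1 and compound 3 cannot be told apart on this read-out. Among the compounds shown here, this is the first direct reading of this position, since compound 1 and compound 2 differ in more than one place: an open octyl chain and a phenyl ring can both stand here, with doses that remain within the usual scatter of each other. No further measurement bears on this result, so the closeness of the two doses remains a plain observation.

The compounds shown leave open whether the same holds for other groups at this place, such as a shorter chain like butyl, a saturated ring like cyclohexyl, or a pyridyl ring. They also leave open whether compound 1 and compound 3 would stay this close on any read-out other than this dose measure.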